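Swapping the aryl amide of compound 3 for a methylpyrazole

The source may report more compounds than this note shows. Statements on the series, on what has been measured and on what is new or still open speak of the compounds shown alone.

Measured so far, in an ADME assay on the whole organism (Rattus norvegicus, strain Wister-Han) for pharmacokinetics, read by LC-MS, at a dose of 3 mg/kg by the oral route; on this read-out higher numbers stand for higher oral bioavailability and lower numbers for lower oral bioavailability:
- compound 1, `CCS(=O)(=O)N1CCC(c2cncc(N3C(=O)c4ccc(Cl)cc4C3(C)C)c2)CC1`, gives 87%
- compound 2, `CCS(=O)(=O)N1CC(Oc2cncc(N3C(=O)c4ccc(Cl)cc4C3(C)C)c2)C1`, gives 45%
- compound 3, `CC1(C)c2cc(Cl)ccc2C(=O)N1c1cncc(OC2CN(C(=O)c3ncccc3Cl)C2)c1`, gives 58%

Compound 3 stands second of the three measured numbers in this assay: its nearest neighbour is compound 2, with a number lower than compound 3 beyond the scatter, and the furthest is compound 1, which is higher than compound 3 beyond the scatter.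

Compound 4, `Cn1cc(C(=O)N2CC(Oc3cncc(N4C(=O)c5ccc(Cl)cc5C4(C)C)c3)C2)cn1`, differs from compound 3 in one place: 1-methyl-1H-pyrazol-4-yl in place of 3-chloropyridin-2-yl on a carbonyl carbon.

Among the compounds with values here, only one measured step touches this part of the molecule, the change at the amine nitrogen in a ring, a number 13 percentage points higher from compound 2 to compound 3 (beyond the scatter). Within the data shown here, that step exchanged an ethylsulfonyl for the whole aryl carbonyl group; the present change keeps the carbonyl and only replaces the aromatic ring on it, and no measured pair shows such an exchange. There is therefore no basis to expect a step in this assay beyond the scatter, and the estimate for compound 4 stays close to compound 3, with a wide range to reflect the missing precedent.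

The step to compound 4 is expected to be a number 8 percentage points lower from compound 3 to compound 4 (within the scatter), and compound 4 is estimated at 50%, between 30% and 75%.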

Compound 4, oral bioavailability: 60%
Compound 4: the middle estimate sits 10 percentage points below what was measured, and the stated range covers the measured number.
By their numbers in this assay, from the lowest: compound 2; then compounds 3 and 4 (each within the scatter of the next); then compound 1.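

In this assay the exchange of 3-chloropyridin-2-yl for 1-methyl-1H-pyrazol-4-yl on a carbonyl carbon gives a number 2 percentage points higher from compound 3 to compound 4 (within the scatter) and so leaves no difference that can be told from the usual scatter, even though the ring changes in size, in its hetero atoms and in the loss of the chlorine. Until now, only one carbonyl group had been compared with ethylsulfonyl on the amine nitrogen in a ring, and the second one gives a number 15 percentage points higher from compound 2 to compound 4 (beyond the scatter) in the same direction as a number 13 percentage points higher from compound 2 to compound 3 (beyond the scatter), so among these three compounds both aromatic carbonyl groups stand above ethylsulfonyl. No measurement at hand accounts for this result.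

On these data alone, it remains open whether the same picture holds for carbonyl groups that carry no aromatic ring, such as a plain acetyl or a cyclopropylcarbonyl, or for a urea built from dimethylamine. As far as these compounds go, it is also open how a pyrazole with a longer chain than methyl on its nitrogen, or with a carboxylic acid or an amine attached, would behave in this assay at this position.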